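Notes on a methyl step in a shared-core series

The compounds below may be only part of what the source reports. "The series", "measured", "known", "first", "only" and "open" are said of these compounds alone.

Three compounds of one shared core have been run in an assay on isolated protein for inhibition of ribosomal protein S6 kinase alpha-5 (Homo sapiens), read by mobility shift assay, tested at 30 uM; a lower number here means less inhibition, a higher number more inhibition at the concentration tested (going by the name of the read-out). Compound 1 `Nc1n[nH]c2cc(-c3cccnc3)[nH]c(=O)c12` gives 36%. Compound 2 `Nc1n[nH]c2cc(-c3ccccn3)[nH]c(=O)c12` gives 35%, which stands lowest of the three numbers, though the gap to compound 1 is within the scatter; compound 3 `COc1ccc(-c2cc3[nH]nc(N)c3c(=O)[nH]2)cc1` gives 62%, beyond the scatter above compound 2. For the measured compounds named here, no two measured compounds differ in a single place, so no measured step is at hand. Compound 4 `Cn1nc(N)c2c(=O)[nH]c(-c3ccccn3)cc21` is not yet measured and differs from compound 2 by methyl in place of hydrogen on an aromatic nitrogen. Going by the values given here, nothing among the measured compounds speaks to this exchange. A small step is expected in this assay, downward if anything, and possibly none beyond the scatter. For compound 4 in this assay an inhibition of 25% is estimated, in the range 5% to 50%. The step this estimate means, a number 10 percentage points lower from compound 2 to compound 4 (within the scatter), is expected to stay modest.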

Compound 4, a percentage reported as inhibition, at one concentration (the size of the read-out at that concentration, not a potency): -4%
Estimate against measurement, compound 4: 29 percentage points above, and the stated range ends above it.
By their numbers in this assay, from the lowest: compound 4; then compounds 2 and 1 (each within the scatter of the next); then compound 3.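

On this position, the first measured step is large: in this assay, methyl in place of hydrogen on the aromatic nitrogen gives a number 39 percentage points lower from compound 2 to compound 4 (beyond the scatter). At this concentration, the hydrogen on that nitrogen therefore matters for inhibition in this pair, and compound 4 at -4% shows no inhibition to speak of. Nothing at hand accounts for the loss.

Still open, going by these compounds, is whether ethyl or a longer chain on this nitrogen behaves as methyl does. Also open, on these data alone, is whether the same exchange on compound 1 or compound 3 gives a step of similar size.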